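This account rests on a few compounds, and the source may have more. Where it says the series, first, only, none or still open, it means among the compounds named here.

Measured so far:
compound 1 `COc1ccc(C(=O)Nc2cc3nc(C4CCCCC4)[nH]c3cc2N(C)C)cc1` — > 100 ug/mL
compound 2 `CN(C)c1cc2[nH]c(C3CCCCC3)nc2cc1NC(=O)c1ccc(OC(F)(F)F)cc1` — > 100 ug/mL

In an ADME assay on Vero cells (Chlorocebus sabaeus) for cytotoxicity, read by resazurin assay, with a stated time of 3 days (on this read-out higher numbers stand for weaker inhibition and lower numbers for stronger inhibition), compound 1 gives only the limit > 100 ug/mL. Compound 2 likewise stops at the limit > 100 ug/mL. The step that the two limits leave unreadable from compound 1 to compound 2 is therefore unreadable because both values rest at the limit of > 100 ug/mL in this assay, at which 2 of the 2 values shown sit. Compound 3 `CCOCCOC(=O)Nc1cc2nc(C3CCCCC3)[nH]c2cc1N(C)C` carries the change (2-ethoxyethoxy in place of 4-methoxyphenyl on a carbonyl carbon). Among the measured compounds shown here, no measured step covers a change of this kind, and the one step recorded shows only that the series sits at the limit. The step of a number no higher from compound 1 to compound 3 (the limit leaves the size open) is thus expected to be none beyond the scatter. Compound 3 is estimated at 100 ug/mL, with a range from 50 ug/mL to 200 ug/mL.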

Compound 3, half-maximal inhibitory concentration: > 100 ug/mL
Compound 3: no number, only a limit; the forecaster's own chance of this, stated with the estimate: 85%; the middle value sits exactly at the limit.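

The step between compound 1 and compound 3 cannot be read in this assay, because both values are limits: the limit of > 100 ug/mL in this assay, at which 3 of the 3 values shown sit.

The compounds shown leave open whether any of these changes shifts the half-maximal inhibitory concentration at all; none of them gives a number.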